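The source may hold more compounds than are shown below. What is called first, only, known or untested is meant among the compounds shown, and "the series" means these compounds.

Measured compounds:
- compound 1 `CC(Oc1nc(N)nc2ccc(-c3cnn(C4CCNCC4)c3)cc12)c1c(Cl)ccc(F)c1Cl`: 7000 nM
- compound 2 `Cn1cc(-c2ccc3ncnc(Nc4ccc(F)c(Cl)c4)c3c2)cn1`: 62700 nM

In a functional assay on MDA-MB-231 cells (Homo sapiens) for antiproliferative activity, read by MTT assay, with a stated time of 72 h (a higher number here means a weaker inhibitor, a lower number a stronger inhibitor), compound 2 gives 62700 nM, the higher of the two numbers; compound 1 gives 7000 nM, a gap beyond the usual scatter. Compound 3 `C#Cc1cccc(Nc2ncnc3ccc(-c4cnn(C)c4)cc23)c1` differs from compound 2 by 3-ethynylphenyl in place of 3-chloro-4-fluorophenyl on a nitrogen on an aromatic ring. For the measured compounds named here, no measured pair shows this exchange, so its effect is unknown. Compound 3 is expected to stay close to compound 2, with a step of a 1.6-fold lower number from compound 2 to compound 3 (0.20 log units; within the scatter) in this assay, a small shift toward a lower number at most. The estimate for compound 3 is 40000 nM, within 10000 nM to 150000 nM.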

Compound 3, half-maximal inhibitory concentration: 16900 nM
For compound 3 the middle estimate is 2.4-fold (0.37 log units) above the measured one; the range from low to high includes it.
By their numbers in this assay, from the lowest: compound 1; then compound 3; then compound 2.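

In this assay, the group on a nitrogen on an aromatic ring proves able to move the number: 3-ethynylphenyl in place of 3-chloro-4-fluorophenyl gives a 3.7-fold lower number from compound 2 to compound 3 (0.57 log units; beyond the scatter). For the compounds shown here, this is the first single-place comparison, as compound 1 differs from compound 2 in more than one place. Nothing available here accounts for the step.

From the compounds shown here alone, whether an unsubstituted phenyl or a propynyl chain at this position would keep the lower number remains open. So does whether an amine on the 3-ethynylphenyl ring would lower it further.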